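A few compounds are considered here, and "the series" means these few. Any claim that something is new, unique, unknown or untested is made for them only; others in the source may bear on it.

Compound 1 `COc1cc(N2C(N)=C(C#N)C(/C=C/c3ccccc3)C3=C2CC(C)(C)CC3=O)cc(OC)c1OC` gives 40% in a functional assay on Ehrlich cells (Mus musculus) for cytotoxicity, tested at 100 ug/mL; on this read-out higher numbers stand for a stronger effect at the one concentration tested and lower numbers for a weaker effect.
Compound 2 `COc1cc(N2C(N)=C(C#N)C(c3ccccc3O)C3=C2CC(C)(C)CC3=O)cc(OC)c1OC` gives 10%.
Compound 3 `COc1cc(N2C(N)=C(C#N)C(c3ccc(C)cc3)C3=C2CC(C)(C)CC3=O)cc(OC)c1OC` gives 90%.

Compound 3 stands highest of the three numbers in this assay. Its nearest neighbour is compound 1, reached by a number 50 percentage points higher from compound 1 to compound 3 (beyond the scatter), and compound 2 lies furthest away, reached by a number 80 percentage points higher from compound 2 to compound 3 (beyond the scatter). The step to compound 4 `COc1cc(N2C(N)=C(C#N)C(c3ccccc3)C3=C2CC(C)(C)CC3=O)cc(OC)c1OC` is hydrogen in place of methyl on an aromatic carbon. Among the compounds with values here, no measured pair shows that exact change. The two steps that lead to compound 3 both exchange the entire group on the saturated ring carbon, and both are large, so the numbers in this assay evidently move with what sits on that carbon. Removing one methyl is a smaller alteration than either of those exchanges, so only part of the difference between compound 3 and compound 1 is likely to be given back. With compound 4 a modest drop is therefore expected, a number 25 percentage points lower from compound 3 to compound 4 (beyond the scatter), leaving it beneath compound 3 yet well clear of compound 2. Compound 4 is estimated at 65% in this assay, between 35% and 90%.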

Compound 4, a percentage reported as activity, at one concentration (the size of the read-out at that concentration, not a potency): 10%
Compound 4: the middle estimate sits 55 percentage points above what was measured, and the stated range ends above it.
By their numbers in this assay, from the lowest: compounds 2 and 4 (each within the scatter of the next); then compound 1; then compound 3.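

In this assay the loss of a single methyl is a large step, with a number 80 percentage points lower from compound 3 to compound 4 (beyond the scatter) for hydrogen in place of methyl, so on this aromatic carbon one methyl separates compound 3 from the level of compound 2. Hydroxy and hydrogen are not told apart here, with no change at the digits printed from compound 2 to compound 4 (within the scatter) in this comparison of the two aromatic groups. The plain phenyl brings no gain over 2-phenylethenyl either, with a number 30 percentage points lower from compound 1 to compound 4 (beyond the scatter) on that exchange, so among these compounds an aromatic ring on the saturated ring carbon does not bring the high number by itself, and only 4-methylphenyl does.

An ethyl, a methoxy or a chlorine on that same aromatic carbon would show whether the high number belongs to methyl alone. The data shown offer no measured explanation for the size of the methyl step.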